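Benzyl for Ethyl at the Ring Carbon of Compound 2

A few compounds are considered here, and "the series" means these few. Any claim that something is new, unique, unknown or untested is made for them only; others in the source may bear on it.

Measured so far:
- compound 1, `C[C@H]1CC(Cl)=C[C@@H](C2CCCCC2)O1`: 38000 nM
- compound 2, `CC[C@H]1CC(Cl)=C([Si](C)(C)C)[C@@H](C2CCCCC2)O1`: 35000 nM

In a functional assay on A2780 cells (Homo sapiens) for antiproliferative activity (a lower number here means a stronger inhibitor of growth, a higher number a weaker inhibitor of growth), compound 2 gives 35000 nM, the lower of the two numbers measured, but compound 1 sits within the scatter of it, so the two cannot be ranked. Both are weak inhibitors of growth.

Compound 3, `C[Si](C)(C)C1=C(Cl)C[C@H](Cc2ccccc2)O[C@@H]1C1CCCCC1`, has not been measured. It differs from compound 2 by phenyl in place of methyl on a saturated chain carbon bound to a saturated ring carbon. Going by the values given here, no measured pair shows what such a change does on this core, so there is no step to lean on.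

A larger group enters on a saturated chain carbon, and an untested change of that kind can move a value either way. The expected step from compound 2 to compound 3 is a modest one, a 1.8-fold lower number from compound 2 to compound 3 (0.24 log units; within the scatter), toward a lower number, with no change beyond the scatter also possible. Compound 3 is thus estimated at 20000 nM, expected to fall between 6000 nM and 60000 nM.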

Compound 3, concentration for total growth inhibition: 78000 nM
Estimate against measurement, compound 3: 3.9-fold (0.59 log units) below, outside the stated range (above it).
By their numbers in this assay, from the lowest: compounds 2 and 1 (each within the scatter of the next); then compound 3.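

In this assay, going by these compounds alone, the change from ethyl to benzyl gives a 2.2-fold higher number from compound 2 to compound 3 (0.35 log units; beyond the scatter) and so provides the first reading at this position, since compound 1 and compound 2 differ in more than one place. The step is modest but beyond the scatter, and it shows that phenyl in place of methyl on this saturated chain carbon goes with weaker growth inhibition, not stronger, on this core. No measurement shown here accounts for the shift.

A single step cannot separate the effect of the aromatic ring from that of a longer chain, and a propyl or a cyclohexylmethyl group at the same carbon would help to tell the two apart. Going by these compounds, whether an amine or a carboxylic acid on this chain would move the number in either direction also remains open.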